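From Phenyl to Methoxy at the Assay Limit

A few compounds are considered here, and "the series" means these few. Any claim that something is new, unique, unknown or untested is made for them only; others in the source may bear on it.

Of the compounds shown here, three on a shared core have been read in an ADME assay on BJ cells (Homo sapiens) for cytotoxicity, read by luminescence, with a stated time of 72 h; a higher number here means that more compound is needed for the effect, a lower number that less compound is needed. Compound 1 (`CCOC(=O)c1c(-c2cccc(-c3ccccc3)c2)[nH]c2cc(OC)ccc2c1=O`) gives > 21500 nM, which is a limit and not a number. Compound 2 (`CCOC(=O)c1c(-c2cccc(OC)c2)[nH]c2cc(OC)ccc2c1=O`) gives > 21500 nM, also a limit. Compound 3 (`CCOC(=O)c1c(-c2cccc(-c3ccccc3)c2)[nH]c2cc(OC)c(OC)cc2c1=O`) gives > 21500 nM, again a limit. Compound 3 therefore has no exact value, and the series offers only (the limit of > 21500 nM in this assay, at which 3 of the 3 values shown sit).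

Compound 4 (`CCOC(=O)c1c(-c2cccc(OC)c2)[nH]c2cc(OC)c(OC)cc2c1=O`) carries methoxy in place of phenyl on an aromatic carbon, meta to a large group, when set against compound 3: methoxy in place of phenyl on an aromatic carbon. The same exchange appears in a step that the two limits leave unreadable from compound 1 to compound 2. The other measured change, methoxy in place of hydrogen on an aromatic carbon, appears in a step that the two limits leave unreadable from compound 1 to compound 3. Neither has a readable size, so no step beyond the scatter and no direction can be expected in this assay. The expected result is a step that the limit leaves unreadable from compound 3 to compound 4, and a further limit reading is likely. Compound 4 is estimated at 25000 nM, with an expected range from 12000 nM to 50000 nM.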

Compound 4, half-maximal effective concentration: > 21500 nM
Compound 4 ended at the assay's limit; the forecaster's own chance of this, stated with the estimate: 90%; the middle value is on the limit's open side.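

Neither the step from compound 3 to compound 4 nor the step from compound 2 to compound 4 can be read, and the series stays at a single reading: the limit of > 21500 nM in this assay, at which 4 of the 4 values shown sit.

The compounds shown leave open how much of any of them is needed for the effect in this assay, and whether either exchange alters that amount.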